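Another Halogenated Carboxybenzyl Group Against Dipeptidyl Peptidase 9

A few compounds are considered here, and "the series" means these few. Any claim that something is new, unique, unknown or untested is made for them only; others in the source may bear on it.

Two measured compounds share one core. Compound 1 `CC#CCn1c(N2CCC[C@@H](N)C2)nc2c1c(=O)n(Cc1cccc(F)c1C(=O)O)c(=O)n2C` carries a 2-carboxy-3-fluorophenyl group on a saturated chain carbon bound to an aromatic nitrogen. In an ADME assay on isolated protein for inhibition of Dipeptidyl peptidase 9 (Homo sapiens), with stated times of 15 min, 60 s and 20 min (a higher number here means a weaker inhibitor, a lower number a stronger inhibitor), compound 1 reports only a limit, > 100000 nM. Compound 2 `CC#CCn1c(N2CCC[C@@H](N)C2)nc2c1c(=O)n(Cc1cc(Br)ccc1C(=O)O)c(=O)n2C` carries a 5-bromo-2-carboxyphenyl group in the same place. In this assay compound 2 likewise reports only a limit, > 100000 nM. Within the data shown here, the one measured step, a step that the two limits leave unreadable from compound 1 to compound 2, cannot be read for size because of the limit of > 100000 nM in this assay, at which 2 of the 2 values shown sit. Compound 2 therefore stands at the limit, with no number of its own beneath it.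

Compound 3 `CC#CCn1c(N2CCC[C@@H](N)C2)nc2c1c(=O)n(Cc1c(Cl)cccc1C(=O)O)c(=O)n2C` is not yet measured. It differs from compound 2 in this way: 2-carboxy-6-chlorophenyl in place of 5-bromo-2-carboxyphenyl on a saturated chain carbon bound to an aromatic nitrogen. Among the measured compounds shown here, the single measured step bears on it as a change at the same place, on a saturated chain carbon bound to an aromatic nitrogen, and it showed no readable size. For the measured compounds named here, with no measured step offering a direction, no step beyond the scatter is expected in this assay. Compound 3 is accordingly expected to sit again at the limit, estimated at 120000 nM with a range of 40000 nM to 400000 nM, the step that the limit leaves unreadable from compound 2 to compound 3 expected to be no real change.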

Compound 3, half-maximal inhibitory concentration: > 100000 nM
Compound 3 was reported as a limit (the forecaster's own chance of this, stated with the estimate: 85%); the middle value is on the limit's open side.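

Compound 3 also gives only a limit in this assay, so its steps from compound 1 and compound 2 cannot be read for size, because all three compounds sit at the same limit: the limit of > 100000 nM in this assay, at which 3 of the 3 values shown sit.

The compounds shown leave open whether any halogenated carboxybenzyl group on the shared core gives a readable value in this assay, and how these groups would rank.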